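A few compounds are considered here, and "the series" means these few. Any claim that something is new, unique, unknown or untested is made for them only; others in the source may bear on it.

Measured compounds in an ADME assay on Huh-7 cells (Homo sapiens) for cytotoxicity; a lower number here means that less compound is tolerated, a higher number that more compound is tolerated:

Compound 1 `Cc1ccccc1-c1nn(-c2ccc(F)cc2F)cc1CN1CCN(c2ccccc2)CC1`: in this assay compound 1 gives > 20000 nM, which is a limit of the assay and not a number.
Compound 2 `CN1CCN(CCCNCc2cn(-c3ccc([N+](=O)[O-])cc3)nc2-c2ccc(OC(F)(F)F)cc2)CC1`: in this assay compound 2 gives 1600 nM.
Compound 3 `Cc1ccccc1CNc1nn(-c2ccc(F)cc2F)cc1CNCCN1CCN(C)CC1`: in this assay compound 3 gives > 20000 nM, again a limit and not a number.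

Where compound 3 stands: only a limit is known for it, and it sits at the limit of > 20000 nM in this assay, at which 2 of the 3 values shown sit. Within the data shown here, compound 2 is the one member of the set that returns a number. Among the measured compounds shown here, no pair of measured compounds differs in a single place, so there is no measured step to lean on for the change ahead.

Compound 4 `CN1CCN(CCNCc2cn(-c3ccc(F)cc3F)nc2Cc2ccccc2)CC1` differs from compound 3 by benzyl in place of (2-methylbenzyl)amino on an aromatic carbon. For the measured compounds named here, with two of three compounds at the limit and no measured step, the expectation is that the step from compound 3 to compound 4 in this assay stays within the scatter, giving an at least 1.3-fold lower number from compound 3 to compound 4 (0.12 log units; that floor lies within the scatter), with a modest chance that compound 4 returns a number just under the limit rather than the limit itself. Compound 4 is therefore estimated at 15000 nM, within a range of 5000 nM to 40000 nM.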

Compound 4, half-maximal cytotoxic concentration: > 20000 nM
Compound 4: only a limit was reported; the forecaster's own chance of this, stated with the estimate: 60%; middle value at least 1.3-fold (0.12 log units) from the limit.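

In this assay compound 4 gives > 20000 nM, a limit of the assay and not a number. Compound 3 also stands only at a limit, and the step between the two compounds cannot be read. The compounds shown leave open whether benzyl in place of (2-methylbenzyl)amino changes the tolerated concentration at all.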